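The source may hold more compounds than are shown below. What is called first, only, known or untested is meant among the compounds shown, and "the series" means these compounds.

Compound 1 `Cc1ccc(NC(=S)OCCNC(=O)c2cccnc2)cc1` gives 18300 nM in an ADME assay for pharmacokinetics, in phosphate buffer, with a stated time of 0.25 h, tested at 60 uM, at a dose of 60 microM; a lower number here means less compound in the circulation, a higher number more compound in the circulation at the dose given.
Compound 2 `CC(C)(Oc1ccc(Cl)cc1)C(=O)NCCOC(=S)Nc1ccc([N+](=O)[O-])cc1Cl` gives 17200 nM in this assay.
Compound 3 `O=C(NCCOC(=S)Nc1ccccc1)c1cccnc1` gives 17800 nM in this assay.

The three values sit close together: compound 3 stands beside compound 1 and compound 2, and its distance to either of them lies within the scatter, so no one of the three can be set apart from the others. Within the data shown here, the single step that joins two measured compounds in one place, a 1.0-fold lower number from compound 1 to compound 3 (0.01 log units; within the scatter), is flat, and it concerns a small change on an aromatic carbon of the same ring that is changed in the new compound.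

Compound 4 `O=C(NCCOC(=S)Nc1ccc(F)cc1)c1cccnc1` differs from compound 3 by fluoro in place of hydrogen on an aromatic carbon. The place is an aromatic carbon of a six-membered aromatic ring of carbon only, para to a large group; read one bond further out, the change is phenyl to 4-fluorophenyl. Among the measured compounds shown here, the only step that bears on it is the flat one from compound 1 to compound 3, and the three measured values leave no room for a trend in this assay. Compound 4 is therefore expected to show no step beyond the scatter, no change at the digits printed from compound 3 to compound 4 (within the scatter). The estimate for compound 4 in this assay is 17800 nM, with a range from 9000 nM to 32000 nM.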

Compound 4, maximal plasma concentration: 15600 nM
For compound 4 the middle estimate is 1.1-fold (0.06 log units) above the measured one; the measured number falls inside the stated range.
By their numbers in this assay, from the lowest: compounds 4, 2, 3 and 1 (each within the scatter of the next).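

Fluoro in place of hydrogen gives a 1.1-fold lower number from compound 3 to compound 4 (0.06 log units; within the scatter), and fluoro in place of methyl gives a 1.2-fold lower number from compound 1 to compound 4 (0.07 log units; within the scatter). The earlier compounds had compared only hydrogen and methyl on this aromatic carbon, para to a large group, whereas hydrogen, methyl and fluoro can now be read together in this assay, and no listed step among them goes beyond the scatter. There is no other information here that would account for this flat reading.

The compounds shown leave open whether an amine, a carboxylic acid, a methoxy group or a longer chain on this same aromatic carbon would give a step beyond the scatter. They also leave open whether fluoro would read the same on another carbon of this ring, since every step here concerns a single place and three small groups.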